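A few compounds are considered here, and "the series" means these few. Any claim that something is new, unique, unknown or untested is made for them only; others in the source may bear on it.

In a functional assay (Homo sapiens) for inhibition (a higher number here means a weaker inhibitor, a lower number a stronger inhibitor), the measured compounds stand as follows:

Compound 1 `CSc1ccccc1CSc1nc(-c2ccc(F)cc2)c(-c2ccncc2)[nH]1`: 6700 nM
Compound 2 `Fc1ccc(-c2[nH]c(SCCc3ccccc3)nc2-c2ccncc2)cc1`: 640 nM
Compound 3 `CSc1ccc(CSc2nc(-c3ccccc3)c(-c3ccncc3)[nH]2)cc1`: 72500 nM

Compound 1 holds the second highest of the three numbers. Compound 2 sits nearest to it with a lower number, and compound 3 lies furthest with a higher number; both gaps are beyond the scatter. Compound 4 `CSc1cc(Cl)cc(CSc2nc(-c3ccc(F)cc3)c(-c3ccncc3)[nH]2)c1O` has not yet been measured. It differs from compound 1 in one place: 5-chloro-2-hydroxy-3-(methylsulfanyl)phenyl in place of 2-(methylsulfanyl)phenyl on a saturated chain carbon bound to a sulfur. Going by the values given here, no step between two measured compounds matches this change, so there is no precedent for its direction. In this assay a small step toward a lower number is expected, one that may well fall within the scatter. For compound 4 the estimate is 4000 nM, in the range 800 nM to 20000 nM, which means an expected step of a 1.7-fold lower number from compound 1 to compound 4 (0.22 log units; within the scatter).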

Compound 4, half-maximal inhibitory concentration: 640 nM
Estimate against measurement, compound 4: 6.3-fold (0.80 log units) above; measured number below the stated range.
By their numbers in this assay, from the lowest: compounds 2 and 4 (each within the scatter of the next); then compound 1; then compound 3.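

In this assay, the group on a saturated chain carbon bound to a sulfur proves able to shift the number well beyond the scatter: 5-chloro-2-hydroxy-3-(methylsulfanyl)phenyl in place of 2-(methylsulfanyl)phenyl gives a 10-fold lower number from compound 1 to compound 4 (1.02 log units; beyond the scatter) on the same core. Going by these compounds alone, this is the first single-place step at this position, and it runs toward a stronger inhibitor. Nothing available accounts for the change. As far as these compounds go, the chloro and hydroxy groups enter together, and which of them carries the step stays open, as does the effect of an amine or a carboxylic acid on the same phenyl.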